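A longer chain on a shared core and cytotoxicity

The source may report more compounds than this note shows. Statements on the series, on what has been measured and on what is new or still open speak of the compounds shown alone.

Compound 1 `CCCCCCCC(=O)c1cc(O)c(O)c(O)c1`, compound 2 `CCCCCCCCC(=O)c1cc(O)c(O)c(O)c1` and compound 3 `CCCCCCCCCCCC(=O)c1cc(O)c(O)c(O)c1` share one core and differ only in the length of the saturated chain that runs out from the carbonyl. In an ADME assay on Vero cells (Chlorocebus sabaeus) for cytotoxicity (a lower number here means a stronger inhibitor, a higher number a weaker inhibitor), compound 1 gives > 1000 nM, which is a limit of the assay rather than a number. Compound 2 likewise gives > 1000 nM, again only a limit. Compound 3 stands at > 1000 nM, also a limit, so its place on the scale is not pinned down. The steps a step that the two limits leave unreadable from compound 1 to compound 2, a step that the two limits leave unreadable from compound 1 to compound 3 and a step that the two limits leave unreadable from compound 2 to compound 3 all stay unreadable because of the limit of > 1000 nM in this assay, at which 3 of the 3 values shown sit. Compound 4 `CCCCCCCCCCCCCCCCC(=O)c1cc(O)c(O)c(O)c1` carries the change (pentyl in place of hydrogen on a saturated chain carbon, ten or more bonds along the chain from a carbonyl carbon). Going by the values given here, none of the measured steps bears on this change in a readable way, so no size or direction of step in this assay can be drawn from them; the three limits only show that every chain length tried so far has left the value beyond the limit. The step from compound 3 to compound 4 is estimated at a step that the limit leaves unreadable from compound 3 to compound 4. Compound 4 is therefore expected to sit near 3000 nM, with an estimated range from 700 nM to 20000 nM, and most likely to be reported again only as a limit.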

Compound 4, half-maximal inhibitory concentration: > 1000 nM
Compound 4: a limit, no number; the forecaster's own chance of this, stated with the estimate: 70%; the middle value does not contradict the limit.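

In this assay compound 4 gives > 1000 nM, which is a limit and not a number. The steps from compound 1, compound 2 and compound 3 to compound 4 therefore cannot be read, because all four compounds share that limit: the limit of > 1000 nM in this assay, at which 4 of the 4 values shown sit.

The compounds shown leave open where each one truly falls on the scale, and whether chain length changes the value at all.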